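Swapping the furan arm on a quinoline diamine for a fluoro-methoxyphenyl

The compounds below may be only part of what the source reports. "The series", "measured", "known", "first", "only" and "open" are said of these compounds alone.

Three compounds share one core and differ only at a remote aromatic carbon. Compound 1 `CC(C)CCc1ccc2c(NCCCNCc3ccco3)ccnc2c1` gives 9.47 in a physicochemical assay for acid dissociation; compound 2 `c1ccc(Oc2ccc3c(NCCCNCc4ccco4)ccnc3c2)cc1` gives 9.28; compound 3 `Fc1ccc(Cc2ccc3c(NCCCNCc4ccco4)ccnc3c2)c(Cl)c1` gives 9.47. The three numbers sit together: a number 0.19 log units lower from compound 1 to compound 2 (within the scatter), no change at the digits printed from compound 1 to compound 3 (within the scatter), a number 0.19 log units higher from compound 2 to compound 3 (within the scatter). Compound 2 holds the lowest of the three, yet its nearest and furthest neighbours both lie within the scatter, so no ordering can be read from it.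

Compound 4 `COc1ccc(F)cc1CNCCCNc1ccnc2cc(Oc3ccccc3)ccc12` differs from compound 2 at the other end of the molecule: 5-fluoro-2-methoxyphenyl in place of furan-2-yl on a saturated chain carbon bound to an amine nitrogen. Cut one bond further out, the difference reads (furan-2-yl)methyl to 5-fluoro-2-methoxybenzyl. For the measured compounds named here, none of the measured steps touches this carbon; each of them changed only the aromatic substituent on the core, and each stayed within the scatter. The data therefore give no direct guide, and a change of no more than modest size is expected, a number 0.22 log units higher from compound 2 to compound 4 (within the scatter). For compound 4 the estimate in this assay is 9.5, with a range from 9.1 to 9.9.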

Compound 4, acid dissociation constant: 9.28
Compound 4: middle estimate off by 0.22 log units, on the high side; the range from low to high includes it.
By their numbers in this assay, from the lowest: compounds 2, 4, 1 and 3 (each within the scatter of the next).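

For the compounds shown here, the first reading at this end of the molecule, on a saturated chain carbon bound to an amine nitrogen, is no change at the digits printed from compound 2 to compound 4 (within the scatter) in this assay. Furan-2-yl, a five-membered aromatic ring with 1 hetero atom and 5 heavy atoms, and 5-fluoro-2-methoxyphenyl, a six-membered aromatic ring of carbon only with 9 heavy atoms, thus give values within the scatter of each other in this one pair, which carries phenoxy on the aromatic carbon. The compounds shown offer no measurement that would account for this result.

As far as these compounds go, whether the same holds with isopentyl or 2-chloro-4-fluorobenzyl on the aromatic carbon remains open. So does the reading for a carboxylic acid, a simple alkyl amine or a longer chain in place of these rings on the saturated chain carbon.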